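The source may report more compounds than this note shows. Statements on the series, on what has been measured and on what is new or still open speak of the compounds shown alone.

Measured so far in an assay on HEK293 cells for positive allosteric modulation of metabotropic glutamate receptor 2 (Rattus norvegicus), read by thallium flux, with a stated time of 2.5 min; a higher number here means that more compound is needed for the effect, a lower number that less compound is needed: compound 1 `Cc1c(OCCCCOCOc2ccc(C(=O)O)cc2)ccc(C(=O)CC2CCCC2)c1O` gives 228 nM; compound 2 `CCC(=O)c1ccc(OCCCCOc2cc(C(=O)O)ccc2OC)c(C)c1O` gives 162 nM; compound 3 `CCCC(=O)c1ccc(OCCCCOc2cc(C(=O)O)ccc2OC)c(C)c1O` gives 103 nM.

Compound 1 has the highest of the three numbers; its gap to compound 2 lies within the scatter, while its gap to compound 3 lies beyond it. Compound 4 `Cc1c(OCCCCOc2ccc(F)c(C(=O)O)c2)ccc(C(=O)CC2CCCC2)c1O` differs from compound 1 by 3-carboxy-4-fluorophenyl in place of (4-carboxyphenoxy)methyl on an oxygen on a saturated carbon. Within the data shown here, the only measured step, a 1.6-fold lower number from compound 2 to compound 3 (0.20 log units; within the scatter), concerns the saturated chain near the carbonyl and does not bear on this change. Compound 2 and compound 3, whose chains end directly on an aryl oxygen as in compound 4, both give lower numbers than compound 1, so a modest decrease is expected, a 1.5-fold lower number from compound 1 to compound 4 (0.18 log units; within the scatter). Compound 4 is therefore estimated at 150 nM, with a range from 60 nM to 400 nM.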

Compound 4, half-maximal effective concentration: 699 nM
Estimate against measurement, compound 4: 4.7-fold (0.67 log units) below, and the stated range ends below it.
By their numbers in this assay, from the lowest: compounds 3, 2 and 1 (each within the scatter of the next, the first and the last beyond it); then compound 4.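

In this assay, among these compounds, 3-carboxy-4-fluorophenyl in place of (4-carboxyphenoxy)methyl gives a 3.1-fold higher number from compound 1 to compound 4 (0.49 log units; beyond the scatter) and so shows what the earlier compounds could not: the number responds to the group carried on this oxygen on a saturated carbon. The swap changes several things at once, since a fluorine enters and the carboxy group and its link to the chain both differ. Nothing measured here explains the step. Open, on these data alone, is which of these differences carries it, and how a chlorine in place of the fluorine, or an amide in place of the carboxylic acid, would read here.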